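The compounds below may be only part of what the source reports. "The series", "measured", "known", "first", "only" and "open" are said of these compounds alone.

Measured in a functional assay on HepG2 cells (Homo sapiens) for cytotoxicity; a lower number here means that less compound is tolerated, a higher number that more compound is tolerated:
- compound 1 `CCCCCCCCCC(=O)Nc1nc(N)nc2c1ncn2[C@H]1CO[C@@H](CO)O1`: > 100000 nM, a limit
- compound 2 `CCCCCCCCCCCCCCCC(=O)Nc1nc(N)nc2c1ncn2[C@H]1CO[C@@H](CO)O1`: > 100000 nM, a limit

Among the compounds with values here, compound 2 stands only at a limit and has no number; the series so far shows (the limit of > 100000 nM in this assay, at which 2 of the 2 values shown sit). Compound 3 `CCCCCCCC/C=C\CCCCCCCC(=O)Nc1nc(N)nc2c1ncn2[C@H]1CO[C@@H](CO)O1` differs from compound 2 by dec-1-en-1-yl in place of octyl on a saturated chain carbon, seven bonds along the chain from a carbonyl carbon, with dec-1-en-1-yl in place of octyl on a saturated chain carbon, seven bonds along the chain from a carbonyl carbon. Within the data shown here, the only measured step, a step that the two limits leave unreadable from compound 1 to compound 2, gives no size to carry over. The expected change in this assay is a number no higher from compound 2 to compound 3 (the limit leaves the size open), estimated as none beyond the scatter, and a further limit is the likeliest report. For compound 3 the estimate is 100000 nM, with an expected range of 50000 nM to 200000 nM.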

Compound 3, half-maximal cytotoxic concentration: 11000 nM
The estimate for compound 3 lay 9.1-fold (0.96 log units) above the measured number, and the stated range ends above it.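

In this assay, the place seven bonds along the chain from a carbonyl carbon now gives a readable change: dec-1-en-1-yl in place of octyl gives an at least 9.0-fold lower number from compound 2 to compound 3 (0.95 log units; beyond the scatter). Dec-1-en-1-yl in place of ethyl at the same place gives an at least 9.0-fold lower number from compound 1 to compound 3 (0.95 log units; beyond the scatter). The fully saturated chains gave no number, and compound 3 alone stands off the limit: the limit of > 100000 nM in this assay, at which 2 of the 3 values shown sit.

The added carbons and the double bond enter together, and the compounds shown do not separate their shares. As far as these compounds go, a fully saturated chain of the length in compound 3 would address this, while a chain ending in an amine remains open.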